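Swapping the Amine Tail on Compound 3

The source may report more compounds than this note shows. Statements on the series, on what has been measured and on what is new or still open speak of the compounds shown alone.

Of the compounds shown here, three sharing one core have been measured in a functional assay on MDA-MB-231 cells (Homo sapiens) for cytotoxicity, read by MTT assay, with a stated time of 72 h; a lower number here means a stronger inhibitor, a higher number a weaker inhibitor. Compound 1 `CN(C)CCCNc1nc(-c2ccc(NC(=O)Nc3ccccc3Cl)cc2)nc2ccsc12` gives 590 nM. Compound 2 `CN(C)CCNc1nc(-c2ccc(NC(=O)Nc3ccc(Cl)cc3)cc2)nc2ccsc12` gives 310 nM. Compound 3 `CN(C)CCNc1nc(-c2ccc(NC(=O)Nc3ccccc3Cl)cc2)nc2ccsc12` gives 550 nM; of the three numbers this is the second highest, closest to compound 1 and furthest from compound 2, yet every gap is within the scatter. Two single changes lead to compound 3: a 1.1-fold lower number from compound 1 to compound 3 (0.03 log units; within the scatter), and a 1.8-fold higher number from compound 2 to compound 3 (0.25 log units; within the scatter). Neither moves the number beyond the scatter.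

Compound 4 `CCN(CC)CCNc1nc(-c2ccc(NC(=O)Nc3ccccc3Cl)cc2)nc2ccsc12` is not yet measured. It differs from compound 3 by diethylamino in place of dimethylamino on a saturated chain carbon, two bonds along the chain from a nitrogen on an aromatic ring. The step from compound 1 to compound 3 touches the same amine tail and is the one that bears on this change; it was small. For the measured compounds named here, no measured pair replaces the methyl groups on that nitrogen with ethyl groups, so the direct effect of the larger amine is unknown. For compound 4 the step in this assay is expected to be a 1.1-fold lower number from compound 3 to compound 4 (0.04 log units; within the scatter), within the scatter. Compound 4 is therefore estimated to give 500 nM, with a range from 200 nM to 1500 nM.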

Compound 4, half-maximal inhibitory concentration: 680 nM
Compound 4: the middle estimate sits 1.4-fold (0.13 log units) below what was measured, within the range that was stated.
By their numbers in this assay, from the lowest: compounds 2, 3, 1 and 4 (each within the scatter of the next, the first and the last beyond it).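

In this assay, for the compounds shown here, the first direct swap of the methyl groups on the tail nitrogen for ethyl groups reads a 1.2-fold higher number from compound 3 to compound 4 (0.09 log units; within the scatter), so at this place on the chain the assay does not tell diethylamino from dimethylamino. The comparison with the longer tail reads a 1.2-fold higher number from compound 1 to compound 4 (0.06 log units; within the scatter), so compound 4 also cannot be told apart from compound 1, and all three amine tails now sit within the scatter of one another when the 2-chlorophenyl group is held fixed. Nothing measured on these compounds speaks to the reason for this result.

On these data alone, whether a tail whose amine is closed into a ring, such as morpholine or piperidine, would stay in the same range remains open, as does the effect of a tail ending in a carboxylic acid. As far as these compounds go, it is also open whether diethylamino would read the same alongside the 4-chlorophenyl group of compound 2.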